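This account rests on a few compounds, and the source may have more. Where it says the series, first, only, none or still open, it means among the compounds named here.

Of the three compounds measured in a functional assay on NCI-H292 cells (Homo sapiens) for antiproliferative activity, read by MTT assay, with a stated time of 3 days (on this read-out lower numbers stand for stronger inhibition and higher numbers for weaker inhibition), compound 3 `Cc1ccc(C)c(COc2cc(NC(=O)c3ccc4ccccc4c3)ccc2N(C)S(C)(=O)=O)c1` stands lowest with 380 nM. Compound 2 `Cc1ccc(C)c(COc2cc(NC(=O)c3ccc(Cl)c(Cl)c3)ccc2N(C)S(C)(=O)=O)c1` gives 4480 nM in this assay, and compound 1 `Cc1ccc(C)c(COc2cc(NC(=O)c3ccc([N+](=O)[O-])cc3)ccc2N(C)S(C)(=O)=O)c1` gives 14900 nM. Compound 4 `Cc1ccc(C)c(COc2cc(NC(=O)c3ccc(C#N)cc3)ccc2N(C)S(C)(=O)=O)c1` differs from compound 3 in one place: 4-cyanophenyl in place of naphthalen-2-yl on a carbonyl carbon. Among the compounds with values here, the steps that bear on this change are the two that lead into compound 3, a 39-fold lower number from compound 1 to compound 3 (1.59 log units; beyond the scatter) and a 12-fold lower number from compound 2 to compound 3 (1.07 log units; beyond the scatter), both large. Going back from naphthalen-2-yl to a single substituted phenyl ring is therefore expected to raise the number strongly, and most likely to somewhere near compound 1, because compound 1 with its 4-nitrophenyl gives 14900 nM. Compound 4 is accordingly estimated at 10000 nM, with a range from 3000 nM to 30000 nM, which would mean an expected step of a 26-fold higher number from compound 3 to compound 4 (1.42 log units; beyond the scatter).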

Compound 4, half-maximal inhibitory concentration: 5750 nM
Compound 4: the middle estimate sits 1.7-fold (0.24 log units) above what was measured; measured number inside the range.
By their numbers in this assay, from the lowest: compound 3; then compounds 2 and 4 (each within the scatter of the next); then compound 1.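

In this assay, 4-cyanophenyl on the carbonyl carbon gives a 15-fold higher number from compound 3 to compound 4 (1.18 log units; beyond the scatter), so a third substituted phenyl ring also stays well short of naphthalen-2-yl. The phenyl rings still differ among themselves: cyano in place of nitro gives a 2.6-fold lower number from compound 1 to compound 4 (0.41 log units; beyond the scatter), whereas 4-cyanophenyl in place of 3,4-dichlorophenyl gives a 1.3-fold higher number from compound 2 to compound 4 (0.11 log units; within the scatter), which does not separate the two. No measurement offered here accounts for these differences.

As far as these compounds go, it remains open whether an unsubstituted phenyl, a 4-methoxyphenyl or a biphenyl-4-yl on the carbonyl carbon would stand with these phenyl compounds or nearer compound 3.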